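An Ethoxy Group Added to Compound 2

This account rests on a few compounds, and the source may have more. Where it says the series, first, only, none or still open, it means among the compounds named here.

Compound 1, `C#CCOc1ccc(-c2cc(-c3ccc(OCC#C)cc3)nc(C)n2)cc1`, gives 7830 nM in an assay on BTI-TN-5B1-4 cells for inhibition of Amine oxidase [flavin-containing] B (Homo sapiens), read by fluorescence and Amplex Red, using microsomes, with a stated time of 30 min; a higher number here means a weaker inhibitor, a lower number a stronger inhibitor.
Compound 2, `C#CCOc1ccc(-c2cc(-c3ccc(OCC#C)cc3)nc(-c3ccccc3)n2)cc1`, gives 12300 nM in this assay.
Compound 3, `C#CCOc1ccccc1-c1cc(-c2ccccc2OCC#C)nc(N)n1`, gives 11100 nM in this assay.

Compound 2 has the highest of these three numbers, yet its gaps to compound 3 and to compound 1 both lie within the scatter, so the three are not separable. Among the measured compounds shown here, the one single-change step, a 1.6-fold higher number from compound 1 to compound 2 (0.20 log units; within the scatter), concerns a different part of the molecule.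

Compound 4, `C#CCOc1ccc(-c2cc(-c3ccc(OCC#C)c(OCC)c3)nc(-c3ccccc3)n2)cc1`, differs from compound 2 in one place: ethoxy in place of hydrogen on an aromatic carbon. For the measured compounds named here, no measured step touches this position, and the only measured step stayed within the scatter, so there is nothing to argue for a large shift. Compound 4 is therefore expected to show a 1.0-fold lower number from compound 2 to compound 4 (0.01 log units; within the scatter). The estimate for compound 4 is 12000 nM, ranging from 4000 nM to 36000 nM.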

Compound 4, half-maximal inhibitory concentration: 29000 nM
Estimate against measurement, compound 4: 2.4-fold (0.38 log units) below; low and high end bracket the measured number.
By their numbers in this assay, from the lowest: compounds 1, 3 and 2 (each within the scatter of the next); then compound 4.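

Placing ethoxy on this aromatic carbon, ortho to a propargyloxy group, gives in this assay the first step here that lies beyond the scatter: a 2.4-fold higher number from compound 2 to compound 4 (0.37 log units; beyond the scatter) and marks a modestly weaker inhibitor. So, unlike the methyl-to-phenyl change, this substitution moves the number measurably, and in the weaker direction. Nothing shown explains the shift.

Ethoxy is the only group at this position among these compounds. Going by these compounds, whether methoxy, a hydroxyl group, fluorine or a longer alkoxy chain would weaken inhibition similarly remains open.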